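A few compounds are considered here, and "the series" means these few. Any claim that something is new, unique, unknown or untested is made for them only; others in the source may bear on it.

Measured in an ADME assay (liver) for pharmacokinetics, with Liver microsome (Homo sapiens) as the target, using microsomes; a lower number here means that the compound disappears faster, a higher number that the compound lasts longer:
compound 1 `CCOc1cc(NC(=O)C2(NC(=O)c3ccc4c(C5CCCC5)c(-c5ncc(Cl)cn5)n(C)c4c3)CCC2)ccc1/C=C/C(=O)OC(=O)C[C@H](O)C(=O)O`: 5.57 h
compound 2 `CCOc1cc(NC(=O)C2(NC(=O)c3ccc4c(C5CCCC5)c(-c5ncc(Cl)cn5)n(C)c4c3)CCC2)ccc1/C=C/C(=O)OCc1ccccc1`: > 5 h

For the measured compounds named here, compound 1 is the only member of the pair with a read number in this assay, namely 5.57 h. Compound 2 returns in this assay a limit, > 5 h, and not a number. The step that the limit leaves unreadable from compound 1 to compound 2 therefore cannot be sized (the limit of > 5 h in this assay, at which 1 of the 2 values shown sits). Compound 3 `CCOc1cc(NC(=O)C2(NC(=O)c3ccc4c(C5CCCC5)c(-c5ncc(Cl)cn5)n(C)c4c3)CCC2)ccc1/C=C/C(=O)OCC(=O)N(C)C(C)C` is not yet measured; it differs from compound 2 by isopropyl(methyl)carbamoyl in place of phenyl on a saturated chain carbon bound to an oxygen next to a carbonyl group. Going by the values given here, no measured step in this assay touches this kind of change, and the one step is unreadable. Compound 2 itself stands only at a limit, so there is no read starting point. The expectation for compound 3 is set near that limit, with no direction, as a step that the limit leaves unreadable from compound 2 to compound 3. Compound 3 is expected to give 5.5 h in this assay, with a range from 2.5 h to 12 h, and a fair chance that only a limit is reported again.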

Compound 3, half-life: 0.65 h
Beside the measured number, compound 3's estimate is 8.5-fold (0.93 log units) above it; the whole stated range lies above it.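

In this assay, this position proves able to move the read-out: with isopropyl(methyl)carbamoyl in place of phenyl on the saturated chain carbon, the series shows an at least 7.6-fold lower number from compound 2 to compound 3 (0.88 log units; beyond the scatter). For the compounds shown here, the (isopropyl(methyl)carbamoyl)methyl group also reads short against the (2-carboxy-2-hydroxyethyl)carbonyl group, with an 8.6-fold lower number from compound 1 to compound 3 (0.93 log units; beyond the scatter), so this is the first sized change at this oxygen. Compound 2 gives only a limit, so the first step can be stated only as a minimum, and the step from compound 1 to compound 2 cannot be read: the limit of > 5 h in this assay, at which 1 of the 3 values shown sits.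

The compounds shown do not separate the contribution of the carbamoyl carbonyl from that of the isopropyl and methyl groups on its nitrogen, and they give no cause for the change. Also open, as far as these compounds go, is how a primary amide, a carboxylic acid or a longer chain on the same carbon would read.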